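This account rests on a few compounds, and the source may have more. Where it says the series, first, only, none or still open, it means among the compounds named here.

Measured compounds:
compound 1, `Cc1ccc(Oc2cccc(COc3ccccc3CCC(=O)OC[C@H]3OCCC[C@H]3OP(=O)(O)OC[C@H](N)C(=O)O)c2)cc1`, giving 15.2%;
compound 2, `N[C@@H](COP(=O)(O)O[C@H]1C=CCO[C@@H]1COC(=O)CCc1ccccc1OCc1cccc(Oc2ccccc2)c1)C(=O)O`, giving 11.7%;
compound 3, `N[C@@H](COP(=O)(O)O[C@H]1CCCO[C@@H]1COC(=O)CCc1ccccc1OCc1cccc(Oc2ccccc2)c1)C(=O)O`, giving 9.8%.

All three were tested in an assay on HEK293-A cells for agonist activity at probable G-protein coupled receptor 34 (Mus musculus), with a stated time of 1.5 h; a lower number here means a smaller maximal response, a higher number a larger maximal response. Compound 3 sits at the low end of the three numbers, yet the gap to compound 2 and the larger gap to compound 1 both lie within the usual scatter of such measurements, so the three compounds cannot be told apart on these data and none is marked out as weaker or stronger than another. Within the data shown here, what the numbers do show is that every compound so far gives only a small maximal response.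

Compound 4, `N[C@@H](COP(=O)(O)O[C@@H]1CCCO[C@@H]1COC(=O)CCc1ccccc1OCc1cccc(Oc2ccccc2)c1)C(=O)O`, has not yet been measured. Compared with compound 3, the change is the two compounds have the same atoms and bonds; at least one stereo element is drawn with a configuration in one of them and without one in the other: 1 of 4 stereo elements differ; a stereocentre at a saturated ring carbon is drawn S in compound 3 and R in compound 4. Nothing is added and nothing is removed.

Among the measured compounds shown here, since no step between two measured compounds is available to set a scale, and the three measured numbers spread over less than the scatter, the expectation for compound 4 in this assay is a step of no real size: a change from compound 3 of about a number 0.2 percentage points higher from compound 3 to compound 4 (within the scatter), which is expected to stay within the scatter. Compound 4 is therefore estimated at 10%, with a likely range from 4% to 20%.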

Compound 4, largest response reached (Emax), in percent of the reference or control that the assay uses: 14.8%
The estimate for compound 4 lay 4.8 percentage points below the measured number, and the stated range covers the measured number.
By their numbers in this assay, from the lowest: compounds 3, 2, 4 and 1 (each within the scatter of the next).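

At the saturated ring carbon where the stereocentre is drawn S in compound 3 and R in compound 4, this assay shows a number 5 percentage points higher from compound 3 to compound 4 (within the scatter), so on these data this single change of configuration does not separate the two compounds. The swap of hydrogen in place of methyl on an aromatic carbon, the other single change now available, shows a number 0.4 percentage points lower from compound 1 to compound 4 (within the scatter) and does not separate its two compounds either, and the maximal response remains small across all four compounds. The stereochemical comparison carries one caution about how firmly the configuration at this carbon can be read: the fact that one of compounds 3 and 4 is drawn with a defined configuration and the other without, at the place where they differ.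

The compounds shown leave open whether any change to the shared core could give a clearly larger maximal response, for example an amide in place of the ester or a longer chain in place of the one that carries it. They also leave open whether a chlorine on the terminal aromatic ring would move the number beyond the usual scatter, and whether the other stereo elements matter in this assay.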